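This account rests on a few compounds, and the source may have more. Where it says the series, first, only, none or still open, it means among the compounds named here.

Compound 2 `CC[C@H](C)[C@H](N)CN(C(=O)[C@@H]1C[C@H]1c1ccccc1)c1ccc(-c2ccc(OC(C)C)cc2)cc1` is one of two compounds that have been measured in a functional assay for agonist activity at G protein-coupled receptor 88 (Homo sapiens), read by HTRF and cAMP accumulation; a lower number here means that less compound is needed, a higher number that more compound is needed for the effect. In this assay compound 2 gives 72 nM, the lowest of the two numbers. Among the compounds with values here, the only other measured compound is compound 1 `CC[C@H](C)[C@H](N)CN(C(=O)[C@@H]1C[C@H]1c1ccccc1)c1ccc(-c2ccc(C(C)(C)C)cc2)cc1`, which differs from compound 2 at a single aromatic carbon; in this assay compound 1 gives 750 nM. Within the data shown here, the step of a 10-fold lower number from compound 1 to compound 2 (1.02 log units; beyond the scatter) is the one measured step in the set.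

Compound 3 `CC[C@H](C)[C@H](N)CN(C(=O)[C@@H]1C[C@H]1c1ccccc1)c1ccc(-c2ccc(OC)cc2)cc1` has not yet been measured in this assay. It differs from compound 2 by methyl in place of isopropyl on an oxygen on an aromatic ring. Among the measured compounds shown here, no measured step exchanges one group on that oxygen for another, so the measured step from compound 1 to compound 2 bears on the new change only in that it touches the same place and shows that this assay responds strongly to what sits there. With so thin a basis, the step of a 2.1-fold higher number from compound 2 to compound 3 (0.32 log units; beyond the scatter) is expected to be moderate and most likely toward a higher number, but it could fall within the scatter. Compound 3 is therefore estimated at 150 nM, within a range from 40 nM to 600 nM.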

Compound 3, half-maximal effective concentration: 120 nM
Compound 3: middle estimate off by 1.3-fold (0.10 log units), on the high side; low and high end bracket the measured number.
By their numbers in this assay, from the lowest: compounds 2 and 3 (each within the scatter of the next); then compound 1.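

With methyl in place of isopropyl on the oxygen, this assay shows a 1.7-fold higher number from compound 2 to compound 3 (0.22 log units; within the scatter) and so does not separate the two compounds, which means that this position tolerates the loss of the two outer carbons of the isopropyl without a readable change. The earlier step had shown only that replacing tert-butyl with isopropoxy matters, whereas the methoxy comparison, a 6.3-fold lower number from compound 1 to compound 3 (0.80 log units; beyond the scatter), shows that a second, smaller group on the oxygen also stands apart from tert-butyl; among the three compounds, both ethers therefore give lower numbers than the tert-butyl compound, and neither goes against this. Nothing at hand explains these numbers or says why the assay responds in this way.

The compounds shown leave open how far the group on the oxygen can vary, for instance whether an ethoxy or a longer chain such as butoxy would stay with these two ethers. They also leave open whether the oxygen itself counts, which a plain isopropyl, a hydroxyl or a dimethylamino group in the same place would test.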